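Isopropyl on the phenyl ring of compound 2

The source may hold more compounds than are shown below. What is called first, only, known or untested is meant among the compounds shown, and "the series" means these compounds.

In an ADME assay on HEK-293T cells (Homo sapiens) for cytotoxicity, read by CCK-8 assay, with a stated time of 48 h (a higher number here means a weaker inhibitor, a lower number a stronger inhibitor), compound 1 (`O=S(=O)(NCCNC(=S)Nc1cc(C(F)(F)F)cc(C(F)(F)F)c1)c1ccc(-c2ccccc2OCc2cccc(O)c2)s1`) reaches only a limit (> 20000 nM) and gives no number. Compound 2 (`O=C(NCCNS(=O)(=O)c1sccc1-c1ccccc1Oc1ccc(O)c(O)c1)Nc1cc(Cl)cc(Cl)c1`) gives 10700 nM and compound 3 (`COc1ccc(Oc2ccccc2-c2ccsc2S(=O)(=O)NCCNC(=S)Nc2cc(C(F)(F)F)cc(C(F)(F)F)c2)cc1OC`) gives 6800 nM in this assay and, of the two numeric values, these lie within the scatter of each other. Compound 4 (`CC(C)c1ccc(Oc2ccc(O)c(O)c2)c(-c2ccsc2S(=O)(=O)NCCNC(=O)Nc2cc(Cl)cc(Cl)c2)c1`) has isopropyl in place of hydrogen on an aromatic carbon, para to a 3,4-dihydroxyphenoxy group (isopropyl in place of hydrogen on an aromatic carbon). Among the measured compounds shown here, no measured pair isolates a single change, so the expectation rests on compound 2 (10700 nM) alone. The estimated step (a 1.4-fold lower number from compound 2 to compound 4 (0.15 log units; within the scatter)) stays within the scatter, leaning slightly toward a lower number. For compound 4 the expected value is 7500 nM (estimated range 2500 nM to 20000 nM).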

Compound 4, half-maximal inhibitory concentration: > 10000 nM
Compound 4 gave a limit, no number; the forecaster's own chance of this, stated with the estimate: 15%; middle value at least 1.3-fold (0.12 log units) away from the limit.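

In this assay compound 4 gives a limit, > 10000 nM, not a number, so the step from compound 2 to compound 4 cannot be read. The compounds shown leave open what isopropyl in place of hydrogen on an aromatic carbon does to the value.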